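The source may report more compounds than this note shows. Statements on the series, on what has been measured and on what is new or still open speak of the compounds shown alone.

The measured compounds:

Compound 1, `COc1cc(Nc2nc(C(=N)Nc3ccc(N4CCN(C)CC4)cc3)cc3c(-c4ccccc4)n[nH]c23)cc(OC)c1OC`, gives 4600 nM in a functional assay on MDA-MB-231 cells (Homo sapiens) for cytotoxicity, read by MTT assay, with a stated time of 72 h; a higher number here means a weaker inhibitor, a lower number a stronger inhibitor.
Compound 2, `CN1CCN(c2ccc(NC(=N)c3cc4c(-c5ccccc5)n[nH]c4c(NC4CCCCC4)n3)cc2)CC1`, gives 1500 nM in this assay.
Compound 3, `COc1ccc(Cn2nc(-c3ccccc3)c3cc(C(=N)Nc4ccccc4)nc(NC4CCCCC4)c32)cc1`, gives 3400 nM in this assay.

Compounds 1 and 2 share the same core and differ in one place only: 3,4,5-trimethoxyphenyl in place of cyclohexyl on a nitrogen on an aromatic ring. This change made a step of a 3.1-fold higher number from compound 2 to compound 1 (0.49 log units; beyond the scatter), so the compound carrying the trimethoxyphenyl group was the weaker inhibitor of the pair.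

Compound 3 has a different core from compound 2; the difference between the two cores is not broken down here. Its value sits close to that of compound 1 and further from that of compound 2.

Compound 4, `COc1ccc(Cn2nc(-c3ccccc3)c3cc(C(=N)Nc4ccccc4)nc(Nc4cc(OC)c(OC)c(OC)c4)c32)cc1`, has not yet been measured. It differs from compound 3 by the same change seen between compounds 2 and 1: 3,4,5-trimethoxyphenyl in place of cyclohexyl on a nitrogen on an aromatic ring. The surroundings of the change are the same in both pairs. Only one earlier example of this change exists among these compounds, and it was made on a different core, so the expectation carries real uncertainty. For the measured compounds named here, it rests on the single earlier step of a 3.1-fold higher number from compound 2 to compound 1 (0.49 log units; beyond the scatter).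

Compound 4 is therefore expected to show a step of a 2.8-fold higher number from compound 3 to compound 4 (0.45 log units; beyond the scatter) in this assay. Compound 4 is estimated at 9500 nM, with a likely range from 4000 nM to 25000 nM.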

Compound 4, half-maximal inhibitory concentration: 42100 nM
Beside the measured number, compound 4's estimate is 4.4-fold (0.65 log units) below it; the measured number lies above the stated range.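

In this assay, putting 3,4,5-trimethoxyphenyl in place of cyclohexyl on the nitrogen made a step of a 12-fold higher number from compound 3 to compound 4 (1.09 log units; beyond the scatter), so the change again gave the weaker inhibitor, but its size did not carry over from the earlier pair: the same change on two cores in this assay, a 3.1-fold higher number (0.49 log units; beyond the scatter) from compound 2 to compound 1 and a 12-fold higher number (1.09 log units; beyond the scatter) from compound 3 to compound 4, 4.0-fold (0.61 log units) apart, beyond the scatter of two such steps

This shows that the direction of the change held on both cores, and neither pair goes against it, while a step measured on one core gave only a rough guide to the size of the step on the other. It does not show which structural difference between the two cores goes with the larger step, since those cores differ in more than one place, and two pairs are too few to support a general rule for the series.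

The compounds shown carry only cyclohexyl or 3,4,5-trimethoxyphenyl on this nitrogen, so they leave open how a plain phenyl ring, a phenyl ring with a single methoxy group or a short chain ending in an amine would compare. They also leave open whether the step would change in size if only one of the differences between the two cores were present.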